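A few compounds are considered here, and "the series" means these few. Any claim that something is new, unique, unknown or untested is made for them only; others in the source may bear on it.

Measured so far in a functional assay on MOLT-4 cells (Homo sapiens), read by cell counting, with a stated time of 72 h; a lower number here means a stronger inhibitor, a higher number a weaker inhibitor:

- compound 1, `Fc1ccc(/N=C/c2ccccc2Cl)cc1Cl`, gives 3.9 ug/mL
- compound 2, `Fc1ccc(/N=C/c2ccccc2Cl)cc1`, gives 0.77 ug/mL

Going by the values given here, compound 2 stands at the lowest of the two numbers; its nearest neighbour is compound 1, and the one step seen so far, a 5.1-fold lower number from compound 1 to compound 2 (0.70 log units; beyond the scatter), lies beyond the scatter.

Compound 3, `Clc1ccccc1/C=N/c1ccc(Br)cc1`, has not yet been measured. It differs from compound 2 by bromo in place of fluoro on an aromatic carbon. Among the compounds with values here, no measured step swaps one halogen for another on that ring: the only known step removes a chloro on the other ring. Within the data shown here, the halogen exchange therefore has no direct precedent here, and no clear direction can be read from the data.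

The expectation for compound 3 is a number close to that of compound 2, at 1 ug/mL within 0.3 ug/mL to 3.5 ug/mL, which would mean a step of a 1.3-fold higher number from compound 2 to compound 3 (0.11 log units; within the scatter) and so nothing beyond the scatter.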

Compound 3, half-maximal inhibitory concentration: 1.5 ug/mL
Compound 3: middle estimate off by 1.5-fold (0.18 log units), on the low side; the range from low to high includes it.
By their numbers in this assay, from the lowest: compounds 2 and 3 (each within the scatter of the next); then compound 1.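

Bromo in place of fluoro on this aromatic carbon gives a 1.9-fold higher number from compound 2 to compound 3 (0.29 log units; within the scatter) in this assay and so leaves the number unchanged within the usual scatter. Going by these compounds alone, this is the first sign that this position accepts more than one halogen without a clear shift in the read-out. Within the data shown here, the only earlier step, which concerned a chloro on an aromatic carbon, lay beyond the scatter, so a change of one halogen does not always matter equally, although two steps are too few to support a rule. Nothing available explains why this exchange shows so little effect.

As far as these compounds go, it remains open whether this position needs a halogen at all. An amine, a methoxy group or a carboxylic acid at the same place would test whether a non-halogen group is accepted as well.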